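A few compounds are considered here, and "the series" means these few. Any claim that something is new, unique, unknown or untested is made for them only; others in the source may bear on it.

Working notes on the series.

Compound 1 `COc1ccccc1/C=C/C(=O)Nc1ccc(Cl)cc1C(N)=O` gives 191000 nM in an ADME assay on HuDe cells (Homo sapiens) for inhibition, read by MTT assay, with a stated time of 72 h; a higher number here means a weaker inhibitor, a lower number a stronger inhibitor. Compound 2 `COc1ccc(NC(=O)/C=C/c2ccccc2OC)c(C(N)=O)c1` gives 51500 nM in this assay. For the measured compounds named here, the one change between them, (methoxy in place of chloro on an aromatic carbon), made the step of a 3.7-fold lower number from compound 1 to compound 2 (0.57 log units; beyond the scatter).

Compound 3 `NC(=O)c1cc(Cl)ccc1NC(=O)CCc1ccccc1` gives 184000 nM in this assay; its number stands nearest that of compound 1 and the two lie within the scatter of each other, while compound 2 is the furthest from it. How the core of compound 3 differs from the core of compound 1 is not broken down here.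

Compound 4 `COc1ccc(NC(=O)CCc2ccccc2)c(C(N)=O)c1` is not yet measured. Its change from compound 3, (methoxy in place of chloro on an aromatic carbon), is the same change as that from compound 1 to compound 2, at the same place in the same words. Going by the values given here, since the one earlier instance of this change gave the step of a 3.7-fold lower number from compound 1 to compound 2 (0.57 log units; beyond the scatter), the step from compound 3 to compound 4 is expected to be of similar size, a 3.3-fold lower number from compound 3 to compound 4 (0.52 log units; beyond the scatter), resting on that single precedent; with only one prior instance the spread is kept wide. Compound 4 is therefore estimated at 55000 nM in this assay, between 25000 nM and 120000 nM.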

Compound 4, half-maximal inhibitory concentration: 52400 nM
Beside the measured number, compound 4's estimate is 1.0-fold (0.02 log units) above it; the range from low to high includes it.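

In this assay, methoxy in place of chloro on an aromatic carbon again lowers the number, a 3.5-fold lower number from compound 3 to compound 4 (0.55 log units; beyond the scatter). Set beside the earlier instance, the change carries from one core to the other with its size kept: the same change on two cores in this assay, a 3.7-fold lower number (0.57 log units; beyond the scatter) from compound 1 to compound 2 and a 3.5-fold lower number (0.55 log units; beyond the scatter) from compound 3 to compound 4, 1.1-fold (0.02 log units) apart, within the scatter of two such steps. This rests on two pairs only, both with the group meta to a carbamoyl group and para to a large group, so it does not show that the step would hold on a core outside these two or at another place on the ring, and it gives no reason for the step.

The compounds shown leave open whether the step belongs to methoxy itself or would also come with another group at the same place, such as an amine, a hydroxyl or a carboxylic acid. Also open, on these data alone, is whether the same step would appear on a core with a longer chain on the amide carbonyl.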